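Aryl versus methyl on the amide nitrogen of a thiophene amide

The source may hold more compounds than are shown below. What is called first, only, known or untested is meant among the compounds shown, and "the series" means these compounds.

Measured so far:
- compound 1, `Cc1ccc(OCC(=O)N(Cc2cccs2)c2cccnc2)cc1`: 198 nM
- compound 2, `Cc1ccc(OCC(=O)N(C)Cc2cccs2)cc1`: 400 nM

Compound 2 has the higher of the two numbers in an assay on HEK293 cells for agonist activity at transient receptor potential cation channel subfamily M member 8 (Homo sapiens), read by fluorescence and calcium flux, with a stated time of 15 min; on this read-out higher numbers stand for an effect only at larger amounts of compound and lower numbers for an effect already at smaller amounts; its nearest neighbour is compound 1, and the step of a 2.0-fold higher number from compound 1 to compound 2 (0.31 log units; beyond the scatter) shows the gap between them. Compound 3, `Cc1ccc(OCC(=O)N(Cc2cccs2)c2ccccc2)cc1`, has not yet been measured in this assay. It differs from compound 2 by phenyl in place of methyl on an amide-type nitrogen. Within the data shown here, only one measured step bears on this change, a 2.0-fold higher number from compound 1 to compound 2 (0.31 log units; beyond the scatter), in which an aryl group on the amide-type nitrogen gave way to methyl and the number rose modestly. Putting an aryl group back in that place is expected to run the other way, so compound 3 is expected to give a modestly lower number than compound 2, a step of about a 2.0-fold lower number from compound 2 to compound 3 (0.30 log units; within the scatter). Compound 3 is therefore estimated at 200 nM in this assay, within a range of 70 nM to 600 nM.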

Compound 3, half-maximal effective concentration: 23 nM
Compound 3: middle estimate off by 8.7-fold (0.94 log units), on the high side, outside the stated range (below it).
By their numbers in this assay, from the lowest: compound 3; then compound 1; then compound 2.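

In this assay, the group on the amide-type nitrogen proves able to move the number much further than the earlier step had shown: phenyl in place of methyl gives a 17-fold lower number from compound 2 to compound 3 (1.24 log units; beyond the scatter), a large step where pyridin-3-yl in place of methyl had been modest. The two aromatic rings are also not interchangeable at this place, as phenyl in place of pyridin-3-yl gives an 8.6-fold lower number from compound 1 to compound 3 (0.93 log units; beyond the scatter). Nothing available accounts for the difference between these groups.

On these data alone, it remains open whether a cyclohexyl ring, a benzyl group or a longer chain such as propyl on this nitrogen would keep the low number seen with phenyl. Also open, as far as these compounds go, is how a chlorine atom or a methoxy group on that phenyl would shift the number, and whether the step would hold with changes elsewhere on the shared core.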